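A side-chain exchange in compound 1, not yet tested

The compounds below may be only part of what the source reports. "The series", "measured", "known", "first", "only" and "open" are said of these compounds alone.

compound 1, `C[C@@H](O)[C@H](NC(=O)CN(c1nc(Cl)nc2[nH]cnc12)C1CC1)C(=O)OCc1ccccc1`: 30.7%
compound 2, `C[C@@H](O)[C@H](NC(=O)CN(c1nc(Cl)nc2[nH]cnc12)C1CC1)C(=O)O`: 37.6%

In a functional assay on the whole organism (Tail, strain ICR) with Mus musculus as the target, in the tail flick test, with a stated time of 120 min, at a dose of 25 umol/kg by the oral route (a lower number here means a weaker effect, a higher number a stronger effect of the compound at the dose given), compound 1 gives 30.7%, the lower of the two numbers; compound 2 gives 37.6%. For the measured compounds named here, the single measured step, a number 6.9 percentage points higher from compound 1 to compound 2 (within the scatter), changes only the ester oxygen and stays within the scatter. Compound 3, `NC(=O)CC[C@H](NC(=O)CN(c1nc(Cl)nc2[nH]cnc12)C1CC1)C(=O)OCc1ccccc1`, differs from compound 1 by 2-carbamoylethyl in place of 1-hydroxyethyl on a saturated chain carbon bound to an amide-type nitrogen and a carbonyl carbon. Going by the values given here, no measured step touches this chain, so the data give no direction for it; the expected step of a number 0.7 percentage points lower from compound 1 to compound 3 (within the scatter) is therefore none beyond the scatter, with wide uncertainty. Compound 3 is estimated to give 30%, between 10% and 55%.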

Compound 3, a percentage reported as activity, at one dose (the size of the read-out at that dose, not a potency): 36%
Compound 3: the middle estimate sits 6 percentage points below what was measured; low and high end bracket the measured number.
By their numbers in this assay, from the lowest: compounds 1, 3 and 2 (each within the scatter of the next).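

In this assay, 2-carbamoylethyl in place of 1-hydroxyethyl on a saturated chain carbon bound to an amide-type nitrogen and a carbonyl carbon gives a number 5.3 percentage points higher from compound 1 to compound 3 (within the scatter), so this exchange leaves the read-out at this dose within the scatter. For the compounds shown here, this is the first reading at this side chain, as the earlier step touched only the ester. No measurement at hand explains the result. On these data alone, whether an amine, a carboxylic acid or a longer chain at this position would move the number stays open, as does whether removing the benzyl group from compound 3 would matter.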